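The source may report more compounds than this note shows. Statements on the series, on what has been measured and on what is new or still open speak of the compounds shown alone.

Compound 2 `COc1cc(C2CC(c3ccccc3)=NN2C(C)=O)ccc1OCc1cn(Cc2ccc([N+](=O)[O-])cc2)nn1` stands lowest of the two numbers recorded in a functional assay on THP-1 cells (Homo sapiens) for inhibition, read by sulforhodamine B assay, tested at 100 uM (a lower number here means less inhibition of growth, a higher number more inhibition of growth at the concentration tested), where compound 2 gives 10%. Its nearest neighbour is compound 1 `COc1cc(C2CC(c3ccc([N+](=O)[O-])cc3)=NN2C(C)=O)ccc1OCc1cn(Cc2ccc([N+](=O)[O-])cc2)nn1`, which in this assay gives 59%; the step of a number 49 percentage points lower from compound 1 to compound 2 (beyond the scatter) shows that the group on this carbon weighs heavily. Compound 3 `COc1cc(C2CC(c3cc(OC)c(OC)c(OC)c3)=NN2C(C)=O)ccc1OCc1cn(Cc2ccc([N+](=O)[O-])cc2)nn1` carries a different change at the same place: 3,4,5-trimethoxyphenyl in place of phenyl on a carbon with a double bond to nitrogen. Going by the values given here, no measured step covers this exchange; only the size of the step from compound 1 to compound 2 suggests a sizeable shift is possible in either direction. Compound 3 is therefore expected near 35%, within 8% to 70%, an estimated step of a number 25 percentage points higher from compound 2 to compound 3 (beyond the scatter).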

Compound 3, percent growth inhibition at one concentration: 43%
Estimate against measurement, compound 3: 8 percentage points below, and the stated range covers the measured number.
By their numbers in this assay, from the lowest: compound 2; then compound 3; then compound 1.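

Going by these compounds alone, at this carbon, in this assay, 3,4,5-trimethoxyphenyl gives a number 33 percentage points higher from compound 2 to compound 3 (beyond the scatter), so 4-nitrophenyl is not the only group here that reads above phenyl. Exchanging 4-nitrophenyl for 3,4,5-trimethoxyphenyl gives a number 16 percentage points lower from compound 1 to compound 3 (beyond the scatter), which separates the two substituted groups and leaves plain phenyl lowest of the three. No supporting data explain either step. Open, going by these compounds, is how an amine or a carboxylic acid on this phenyl would read. Also open, on these data alone, is whether a single methoxy group would carry part of the trimethoxy step.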